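Swapping the pyridine ring for plain phenyl

A few compounds are considered here, and "the series" means these few. Any claim that something is new, unique, unknown or untested is made for them only; others in the source may bear on it.

- compound 1 `CC(C)NC(=O)[C@H]1CC[C@@H](n2/c(=N/C(=O)c3ccc(C#N)c(F)c3)[nH]c3ccc(CN4CCC(C(C)(C)O)CC4)cc32)CC1` gives 29 mL.min-1.g-1
- compound 2 `CC(C)NC(=O)[C@H]1CC[C@@H](n2/c(=N/C(=O)c3cccc(C#N)c3)[nH]c3ccc(CN4CCC(C(C)(C)O)CC4)cc32)CC1` gives 17 mL.min-1.g-1
- compound 3 `CC(C)NC(=O)[C@H]1CC[C@@H](n2/c(=N/C(=O)c3cccnc3)[nH]c3ccc(CN4CCC(C(C)(C)O)CC4)cc32)CC1` gives < 14 mL.min-1.g-1 (a limit of the assay, not a number)

All three readings come from an in vitro ADME assay on microsomes from liver (Rattus norvegicus) for metabolic stability; a lower number here means slower removal, a higher number faster removal of the compound.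

Compound 3 stands at the limit of < 14 mL.min-1.g-1 in this assay, at which 1 of the 3 values shown sits. Its true value is therefore not known, and that limit is the only fixed point for the next step.

Compound 4 `CC(C)NC(=O)[C@H]1CC[C@@H](n2/c(=N/C(=O)c3ccccc3)[nH]c3ccc(CN4CCC(C(C)(C)O)CC4)cc32)CC1` has not been measured yet. It differs from compound 3 by one change: phenyl in place of pyridin-3-yl on a carbonyl carbon. In words, this is phenyl in place of pyridin-3-yl on a carbonyl carbon.

Within the data shown here, no measured step makes exactly this swap, but three change the group at the same place. The first is a 1.7-fold lower number from compound 1 to compound 2 (0.23 log units; within the scatter). The second is an at least 2.0-fold lower number from compound 1 to compound 3 (0.31 log units; beyond the scatter). The third is an at least 1.2-fold lower number from compound 2 to compound 3 (0.08 log units; that floor lies within the scatter).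

Compound 4 keeps a ring of carbon only, as compound 2 does at 17 mL.min-1.g-1, so a value near that of compound 2 seems the best guess. The expected result is a small move to a higher number, probably within the scatter, estimated as an at least 1.2-fold higher number from compound 3 to compound 4 (0.10 log units; that floor lies within the scatter).

For compound 4 the estimated value in this assay is 18 mL.min-1.g-1, with an expected range from 10 mL.min-1.g-1 to 32 mL.min-1.g-1.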

Compound 4, intrinsic clearance in microsomes: 21 mL.min-1.g-1
Compound 4: middle estimate off by 1.2-fold (0.07 log units), on the low side, within the range that was stated.
By their numbers in this assay, from the lowest: compounds 2, 4 and 1 (each within the scatter of the next). At a limit, below all of these: compound 3.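

In this assay, phenyl in place of the substituted rings gives a 1.2-fold higher number from compound 2 to compound 4 (0.09 log units; within the scatter) and a 1.4-fold lower number from compound 1 to compound 4 (0.14 log units; within the scatter), so the three rings of carbon only in compounds 1, 2 and 4 cannot be told apart at this carbonyl carbon. Taking away the cyano group, with or without the fluoro group, therefore has no readable effect on the number here. The new swap, which replaces pyridin-3-yl with phenyl and so removes one hydrogen-bond acceptor, gives an at least 1.5-fold higher number from compound 3 to compound 4 (0.17 log units; that floor lies within the scatter), so its floor alone does not establish a real difference, and the true step may be larger. Compound 3 carries a limit of the assay, not a number: the limit of < 14 mL.min-1.g-1 in this assay, at which 1 of the 4 values shown sits.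

The compounds shown leave open how the number would respond to a different kind of group on this carbonyl carbon, such as a saturated cyclohexyl ring, or to an amine or a carboxylic acid on the phenyl ring. They also leave open how large the step from pyridin-3-yl to phenyl really is, and whether it would look the same with another group elsewhere on the shared core.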